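The source may report more compounds than this note shows. Statements on the series, on what has been measured and on what is new or still open speak of the compounds shown alone.

Working notes on the phthalimide-bearing series. Compound 1 `Cc1ccc(C(=O)CSc2nnc(C)n2N2C(=O)c3ccccc3C2=O)cc1`, compound 2 `CCc1nnc(SCc2ccccc2)n1N1C(=O)c2ccccc2C1=O` and compound 3 `CCc1nnc(SCC(=O)c2ccc(Cl)cc2)n1N1C(=O)c2ccccc2C1=O` share one core and differ only in the group carried by the sulfur. In a functional assay on PC-3M cells (Homo sapiens) for cytotoxicity, read by MTT assay, with a stated time of 48 h (a higher number here means a weaker inhibitor, a lower number a stronger inhibitor), compound 1 gives only the limit > 200000 nM. Compound 2 likewise gives only the limit > 200000 nM. Compound 3 again gives only the limit > 200000 nM. Compound 3 therefore stands at the same limit as the other two measured compounds, and the step that the two limits leave unreadable from compound 2 to compound 3 cannot be read; the limit of > 200000 nM in this assay, at which 3 of the 3 values shown sit, holds for every value shown.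

Compound 4 `CCc1nnc(SCC(=O)c2ccc(C)cc2)n1N1C(=O)c2ccccc2C1=O` is the next member, to be measured in this assay. The change from compound 3 is methyl in place of chloro on an aromatic carbon. Among the compounds with values here, no measured step bears on this change: the one step recorded is unreadable, and all three values sit at the limit. Nothing in the data suggests a size for the step that the limit leaves unreadable from compound 3 to compound 4 that is expected, and the expectation is that compound 4 also fails to reach a readable potency. For compound 4 the estimate in this assay is 250000 nM, with a range from 80000 nM to 1000000 nM, most probably reported as a limit.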

Compound 4, half-maximal inhibitory concentration: > 200000 nM
Compound 4 ended at the assay's limit (the forecaster's own chance of this, stated with the estimate: 85%); the middle value does not contradict the limit.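

In this assay compound 4 gives > 200000 nM, which is a limit and not a number, so its steps from compound 1, compound 2 and compound 3 cannot be read: the limit of > 200000 nM in this assay, at which 4 of the 4 values shown sit. The compounds shown leave open whether any group on the sulfur gives a readable potency.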